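The source may report more compounds than this note shows. Statements on the series, on what has been measured and on what is new or still open speak of the compounds shown alone.

Compound 3 `CC(C)n1ncc2c(C(=O)NCc3cn(-c4cccc(F)c4)nn3)cccc21` stands at the edge of what a functional assay on MGC-803 cells (Homo sapiens) for inhibition, read by MTT assay, with a stated time of 72 h (a higher number here means a weaker inhibitor, a lower number a stronger inhibitor), can report: in this assay compound 3 gives > 40000 nM, a limit and not a number. Compound 1 `CC(C)n1ncc2c(C(=O)NCc3cn(-c4ccc(I)cc4)nn3)cccc21` likewise gives only a limit in this assay, > 40000 nM. Compound 2 `CC(C)n1ncc2c(C(=O)NCc3cn(-c4ccc(F)cc4)nn3)cccc21` too gives only a limit in this assay, > 40000 nM. Because all three values sit at the limit of > 40000 nM in this assay, at which 3 of the 3 values shown sit, the steps a step that the two limits leave unreadable from compound 1 to compound 2, a step that the two limits leave unreadable from compound 1 to compound 3 and a step that the two limits leave unreadable from compound 2 to compound 3 cannot be read in size. Compound 4 `CC(C)n1ncc2c(C(=O)NCc3cn(-c4ccc([N+](=O)[O-])cc4)nn3)cccc21` carries the change (4-nitrophenyl in place of 3-fluorophenyl on an aromatic nitrogen). Going by the values given here, none of the measured steps offers a readable size that bears on this change, so no direction beyond the scatter can be drawn from them. The value of compound 4 in this assay is estimated at 40000 nM, between 10000 nM and 120000 nM. The expected step is a number no higher from compound 3 to compound 4 (the limit leaves the size open).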

Compound 4, half-maximal inhibitory concentration: > 40000 nM
Compound 4 gave a limit, no number; the forecaster's own chance of this, stated with the estimate: 70%; the middle value lies on the limit itself.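

Compound 4 also gives only a limit in this assay, > 40000 nM. Its steps from compound 1, compound 2 and compound 3 cannot be read in size: the limit of > 40000 nM in this assay, at which 4 of the 4 values shown sit. The compounds shown leave open how strongly any of them inhibits in this assay, and whether the group on the aromatic nitrogen changes this at all.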